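Cyclopropyl for methyl on the ring amine of compound 2

The source may report more compounds than this note shows. Statements on the series, on what has been measured and on what is new or still open speak of the compounds shown alone.

Compound 2 `CN1CCN(c2ccn3c(-c4ccc(NC(=O)c5ccc([N+](=O)[O-])o5)cc4)cnc3c2)CC1` is the reference here. For the measured compounds named here, in a functional assay on AGS cells (Homo sapiens) for antiproliferative activity, read by CCK-8 assay, with a stated time of 72 h (on this read-out higher numbers stand for weaker inhibition and lower numbers for stronger inhibition), compound 2 gives 2340 nM, the highest of the two numbers measured so far; compound 1 `CC(=O)N1CC=C(c2ccn3c(-c4ccc(NC(=O)c5ccc([N+](=O)[O-])o5)cc4)cnc3c2)CC1` gives 410 nM, and the step of a 5.7-fold higher number from compound 1 to compound 2 (0.76 log units; beyond the scatter) exchanges the whole group on the aromatic carbon of the shared core. Compound 3 `O=C(Nc1ccc(-c2cnc3cc(N4CCN(C5CC5)CC4)ccn23)cc1)c1ccc([N+](=O)[O-])o1` carries a smaller change: cyclopropyl in place of methyl on an amine nitrogen in a ring. Going by the values given here, no measured pair alters this nitrogen substituent; the one measured step, a 5.7-fold higher number from compound 1 to compound 2 (0.76 log units; beyond the scatter), concerns a different part of the molecule and does not bear on it directly. The step of a 1.2-fold lower number from compound 2 to compound 3 (0.07 log units; within the scatter) is therefore expected to be small, not beyond the usual scatter. For compound 3 the expected value in this assay is 2000 nM, with a range from 700 nM to 6000 nM.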

Compound 3, half-maximal inhibitory concentration: 1920 nM
Beside the measured number, compound 3's estimate is 1.0-fold (0.02 log units) above it; low and high end bracket the measured number.
By their numbers in this assay, from the lowest: compound 1; then compounds 3 and 2 (each within the scatter of the next).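

In this assay, a 1.2-fold lower number from compound 2 to compound 3 (0.09 log units; within the scatter) shows that cyclopropyl on this amine nitrogen, with its three carbons in place of the single carbon of methyl, gives no change that can be told from the scatter. The gap to compound 1 remains with the new substituent, with a 4.7-fold higher number from compound 1 to compound 3 (0.67 log units; beyond the scatter), so the 4-cyclopropylpiperazin-1-yl group, like the 4-methylpiperazin-1-yl group, gives a number beyond the scatter on the weaker side of compound 1. No measurement at hand accounts for either step.

The compounds shown leave open whether this nitrogen tolerates a hydrogen, a longer chain such as 2-hydroxyethyl, or a chain ending in a carboxylic acid. They also leave open which part of the group on compound 1 carries its lower number, since ring and substituent differ together in each step from it.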